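The compounds below may be only part of what the source reports. "The series", "measured", "known", "first", "only" and "open" are said of these compounds alone.

For the measured compounds named here, compound 2, with the structure `Clc1ccc(COc2ccc(/C=C/C(/C=C/c3ccccn3)=N/Oc3ncnc4cc(Cl)ccc34)cc2)c(Cl)c1`, is the weaker of the two compounds measured so far. Going by the values given here, in a functional assay on SMMC-7721 cells (Homo sapiens) for inhibition, read by MTT assay, with a stated time of 72 h, tested at 10 uM (a higher number here means a stronger effect of the compound at the concentration tested, a lower number a weaker effect), compound 2 gives 23.6%, the lowest of the two numbers known. Among the compounds with values here, its only neighbour is compound 1, the structure `Clc1ccc(COc2ccc(/C=C/C(/C=C/c3ccccn3)=N/Oc3ncnc4ccccc34)cc2)c(Cl)c1`, which differs in one place and in this assay gives 89.6%. That single measured change is a chloro in place of hydrogen on an aromatic carbon of the shared core, and it shows a number 66 percentage points lower from compound 1 to compound 2 (beyond the scatter).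

Compound 3, the structure `Cc1cccc(COc2ccc(/C=C/C(/C=C/c3ccccn3)=N/Oc3ncnc4cc(Cl)ccc34)cc2)c1`, is not yet measured. It differs from compound 2 in one place: 3-methylphenyl in place of 2,4-dichlorophenyl on a saturated chain carbon bound to an oxygen on an aromatic ring. Within the data shown here, none of the measured steps touches this part of the molecule; the one step known, from compound 1 to compound 2, sits on the shared core, not on the benzyl group. So no measured step bears directly on this change, and the data give no basis for expecting a shift beyond the scatter in either direction. Compound 3 is therefore expected to give 30% in this assay, within 5% to 70%. This estimate means a number 6.4 percentage points higher from compound 2 to compound 3 (within the scatter), with wide uncertainty.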

Compound 3, a percentage reported as inhibition, at one concentration (the size of the read-out at that concentration, not a potency): 95.6%
For compound 3 the middle estimate is 65.6 percentage points below the measured one, outside the stated range (above it).
By their numbers in this assay, from the lowest: compound 2; then compounds 1 and 3 (each within the scatter of the next).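

For the compounds shown here, the benzyl end of the molecule, untouched by the earlier step, turns out to matter a great deal: in this assay, the single change at this end, which takes away 2,4-dichlorophenyl and brings in 3-methylphenyl, gives a number 72 percentage points higher from compound 2 to compound 3 (beyond the scatter). Compound 2 and compound 3 both carry the chloro on the shared core, so that chloro does not by itself hold the number down, and the low value of compound 2 holds only alongside the 2,4-dichlorophenyl group. Nothing available explains why this change has so large an effect.

The change removes two chlorines and adds one methyl in a single move, so the compounds shown cannot tell whether losing the chlorines or gaining the methyl matters more, and a plain phenyl or a 3-chlorophenyl at this place would help to separate the two. Going by these compounds alone, they also leave open whether the chloro on the core would cost anything alongside 3-methylphenyl, since its only measured step carries the 2,4-dichlorophenyl group.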